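Moving an amino group on a quinoxaline sulfone series

A few compounds are considered here, and "the series" means these few. Any claim that something is new, unique, unknown or untested is made for them only; others in the source may bear on it.

Of the compounds shown here, three from one series have been tested in a functional assay on PC-3 cells (Homo sapiens) for cytotoxicity, read by MTT assay, with a stated time of 72 h; on this read-out lower numbers stand for stronger inhibition and higher numbers for weaker inhibition. Compound 1 `Nc1ccc(Nc2nc3ccccc3nc2S(=O)(=O)c2ccccc2)cc1` gives 5830 nM in this assay. Compound 2 `Nc1cccc(Nc2nc3ccccc3nc2S(=O)(=O)c2ccccc2)c1` gives 2150 nM, and compound 3 `COc1ccc(S(=O)(=O)c2nc3ccccc3nc2Nc2ccc(N)cc2)cc1` gives 9640 nM.

Two single changes link these compounds. From compound 1 to compound 2 the change is 3-aminophenyl in place of 4-aminophenyl on a nitrogen on an aromatic ring and the step is a 2.7-fold lower number from compound 1 to compound 2 (0.43 log units; beyond the scatter). From compound 1 to compound 3 the change is methoxy in place of hydrogen on an aromatic carbon and the step is a 1.7-fold higher number from compound 1 to compound 3 (0.22 log units; within the scatter), so the cores of compound 3 and compound 4 differ from those of compound 1 and compound 2 only in that methoxy group. Within the data shown here, compound 2 and compound 3 have no direct step between them; their two values simply show the lowest and the highest numbers in this small set.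

Compound 4 `COc1ccc(S(=O)(=O)c2nc3ccccc3nc2Nc2cccc(N)c2)cc1` has not been measured yet. It relates to compound 3 exactly as compound 2 relates to compound 1: the difference is 3-aminophenyl in place of 4-aminophenyl on a nitrogen on an aromatic ring, and the place of the change is described in the same words for both pairs, so it is the same change, made once on each core. Among the measured compounds shown here, the only guide to its size is the single earlier example. On that basis the step from compound 3 to compound 4 is expected to be about a 2.7-fold lower number from compound 3 to compound 4 (0.43 log units; beyond the scatter), resting on a 2.7-fold lower number from compound 1 to compound 2 (0.43 log units; beyond the scatter). Compound 4 is therefore estimated at 3600 nM in this assay, with a plausible range from 1500 nM to 8500 nM, because the value of compound 3 is 9640 nM and one earlier example is a thin basis.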

Compound 4, half-maximal inhibitory concentration: 8600 nM
For compound 4 the middle estimate is 2.4-fold (0.38 log units) below the measured one, outside the stated range (above it).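

In this assay, moving the amino group on the methoxy core gives a 1.1-fold lower number from compound 3 to compound 4 (0.05 log units; within the scatter), so this step stays within the scatter while the same move on the core of compound 1 went beyond it, yet the two steps cannot be told apart: the same change on two cores in this assay, a 2.7-fold lower number (0.43 log units; beyond the scatter) from compound 1 to compound 2 and a 1.1-fold lower number (0.05 log units; within the scatter) from compound 3 to compound 4, 2.4-fold (0.38 log units) apart, within the scatter of two such steps The methoxy change, read on the 3-aminophenyl compounds, gives a 4.0-fold higher number from compound 2 to compound 4 (0.60 log units; beyond the scatter), which goes beyond the scatter where its earlier counterpart did not, but again the two steps cannot be told apart: the same change on two cores in this assay, a 1.7-fold higher number (0.22 log units; within the scatter) from compound 1 to compound 3 and a 4.0-fold higher number (0.60 log units; beyond the scatter) from compound 2 to compound 4, 2.4-fold (0.38 log units) apart, within the scatter of two such steps The results are therefore compatible with each change carrying from one core to the other, but they do not prove it, as two pairs cannot show whether the amino move has the same effect on both cores or a weaker one on the methoxy core.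

The compounds shown leave open what would happen with a different group in place of the amino group, such as a hydroxyl or a carboxylic acid, or in place of the methoxy, such as a fluorine or a longer ether chain. They also leave open whether these steps would look the same in any other assay.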